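The compounds below may be only part of what the source reports. "The series", "measured", "known", "first", "only" and "open" are said of these compounds alone.

Measured so far:
compound 1, `COc1cc(/C=C/C(=O)OCCOc2no[n+]([O-])c2S(=O)(=O)c2ccccc2)ccc1O` — 985000 nM
compound 2, `O=C(/C=C/c1ccc(O)c(O)c1)OCCOc1no[n+]([O-])c1S(=O)(=O)c1ccccc1` — 158000 nM

In an unclassified assay for inhibition, read by fluorescence and spectrophotometry, with a stated time of 40 h (a higher number here means a weaker inhibitor, a lower number a stronger inhibitor), compound 2 gives the lowest of the two numbers; its nearest neighbour is compound 1, with 985000 nM in this assay. Among the measured compounds shown here, the one measured step, a 6.2-fold lower number from compound 1 to compound 2 (0.79 log units; beyond the scatter), runs in that direction, so the free hydroxyls on the aromatic ring of compound 2 go with the stronger inhibition seen here.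

Compound 3, `O=C(/C=C/c1ccccc1)OCCOc1no[n+]([O-])c1S(=O)(=O)c1ccccc1`, is not yet measured. It differs from compound 2 by phenyl in place of 3,4-dihydroxyphenyl on a double-bonded chain carbon bound to a double-bonded chain carbon. This change removes both hydroxyls rather than uncapping one, and it bears on the same part of the structure as the step from compound 1 to compound 2. A step in the opposite direction, a rise in the number, is therefore expected, and probably larger than the measured step, as a 16-fold higher number from compound 2 to compound 3 (1.20 log units; beyond the scatter). For compound 3 the expected value in this assay is 2500000 nM, with a range of 800000 nM to 8000000 nM.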

Compound 3, half-maximal inhibitory concentration: > 10000000 nM
Compound 3 gave a limit, no number; the forecaster's own chance of this, stated with the estimate: 30%; middle value at least 4.0-fold (0.60 log units) away from the limit.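

In this assay compound 3 gives a limit and not a number: the limit of > 10000000 nM in this assay, at which 1 of the 3 values shown sits.

Phenyl in place of 3,4-dihydroxyphenyl on a double-bonded chain carbon bound to a double-bonded chain carbon gives an at least 63-fold higher number from compound 2 to compound 3 (1.80 log units; beyond the scatter), and phenyl in place of 4-hydroxy-3-methoxyphenyl gives an at least 10-fold higher number from compound 1 to compound 3 (1.00 log units; beyond the scatter). The earlier pair compared only a free hydroxyl with a methoxy, whereas these steps show that the oxygen-bearing aromatic rings of both compound 1 and compound 2 go with lower numbers than the bare phenyl, and none of the three compounds goes against this.

As far as these compounds go, whether a single hydroxyl on the phenyl, with no methoxy, is enough remains open. So does how an amine or a carboxylic acid on this ring would compare with the hydroxyls.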